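The compounds below may be only part of what the source reports. "The series", "measured", "known", "first", "only" and "open" are said of these compounds alone.

Compound 1 `C[C@H](Nc1nc2cc(Cl)c(F)cc2s1)c1ccccc1` belongs to a small set that shares one core and varies the group on the chain carbon attached to its aromatic nitrogen. Going by the values given here, in a functional assay on HeLa cells (Homo sapiens) for cytotoxicity, read by MTT assay, with a stated time of 24 h (on this read-out lower numbers stand for stronger inhibition and higher numbers for weaker inhibition), compound 1 gives 58900 nM, and among the two numbers known it stands next to compound 2 `CC[C@H](Nc1nc2cc(Cl)c(F)cc2s1)c1ccccc1`, which in this assay gives 53300 nM. The step of a 1.1-fold lower number from compound 1 to compound 2 (0.04 log units; within the scatter) is within the scatter, so the two compounds cannot be told apart. Compound 3 `COc1ccc([C@H](C)Nc2nc3cc(Cl)c(F)cc3s2)cc1` carries a methoxy on its phenyl, but in this assay compound 3 gives "not determined" (no result reported), so no number is available for it.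

Compound 4 `C[C@H](Nc1nc2cc(Cl)c(F)cc2s1)C1CCCCC1` differs from compound 1 in one place: cyclohexyl in place of phenyl on a saturated chain carbon bound to a nitrogen on an aromatic ring and a saturated chain carbon. Among the compounds with values here, no measured step covers this exchange. Within the data shown here, the only step available, from compound 1 to compound 2, alters the chain rather than the ring, and it was within the scatter, so it gives no pointer to a direction for this assay. With nothing in the data pointing up or down, and both known numbers lying close together, compound 4 is expected to show a step of a 1.1-fold lower number from compound 1 to compound 4 (0.03 log units; within the scatter) that stays within the scatter. Compound 4 is therefore estimated at 55000 nM, with a range from 20000 nM to 150000 nM.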

Compound 4, half-maximal inhibitory concentration: 72500 nM
Compound 4: middle estimate off by 1.3-fold (0.12 log units), on the low side; measured number inside the range.
By their numbers in this assay, from the lowest: compounds 2, 1 and 4 (each within the scatter of the next).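

Exchanging phenyl for cyclohexyl on the saturated chain carbon gives a 1.2-fold higher number from compound 1 to compound 4 (0.09 log units; within the scatter) in this assay, so at this place a six-membered aromatic ring of carbon only and a six-membered non-aromatic ring of carbon only cannot be told apart on this read-out. The earlier step, a 1.1-fold lower number from compound 1 to compound 2 (0.04 log units; within the scatter), touched only the chain, whereas this one replaces the ring itself, and the two single exchanges made on compound 1 now both stay within the scatter. No measurement of any other kind bears on this result, so the data offer no account of it.

The compounds shown leave open whether a ring that carries a substituent, such as a carboxylic acid or an amine, or a ring containing nitrogen, such as pyridine or piperidine, would shift the number beyond the scatter at this place. They also leave open what a much smaller group such as cyclopropyl, or a longer chain between the ring and the nitrogen, would do in this assay.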